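Swapping 4-Methylphenyl for Allyl in a Paw Edema Series

The compounds below may be only part of what the source reports. "The series", "measured", "known", "first", "only" and "open" are said of these compounds alone.

Measured compounds:
compound 1 `Cc1ccc(-n2c(-c3cc(-c4ccc(F)cc4F)ccc3O)n[nH]c2=S)cc1` — 51.6%
compound 2 `C=CCNc1nnc(-c2cc(-c3ccc(F)cc3F)ccc2O)o1` — 36.6%
compound 3 `COc1ccc(Nc2nnc(-c3cc(-c4ccc(F)cc4F)ccc3O)s2)cc1` — 55.3%

In a functional assay on the whole organism (strain BALB/c) for inhibition, with Mus musculus as the target, read by paw edema, with a stated time of 4 h, at a dose of 50 mg/kg by the oral route (on this read-out lower numbers stand for less inhibition and higher numbers for more inhibition at the one dose given (going by the name of the read-out)), compound 1 gives 51.6%, the second highest of the three numbers. Compound 3 gives 55.3%, a number within the usual scatter of that of compound 1, so the two cannot be told apart. Compound 2 gives 36.6%, a number beyond the scatter below compound 1. Compound 4 `C=CCn1c(-c2cc(-c3ccc(F)cc3F)ccc2O)n[nH]c1=S` has not been measured. It differs from compound 1 in one place: allyl in place of 4-methylphenyl on an aromatic nitrogen. Within the data shown here, no measured pair isolates this change, so its effect is unknown. Because compound 2 with its own allyl group gives 36.6%, a drop of similar size is expected here. The step of a number 9.6 percentage points lower from compound 1 to compound 4 (within the scatter) is expected to be downward, roughly at the edge of the scatter. For compound 4 the expected value is 42%, with a range from 28% to 56%.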

Compound 4, a percentage reported as inhibition, in the whole organism at one dose (the size of the read-out at that dose, not a potency): 73%
Compound 4: middle estimate off by 31 percentage points, on the low side, outside the stated range (above it).
By their numbers in this assay, from the lowest: compound 2; then compounds 1 and 3 (each within the scatter of the next); then compound 4.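

With allyl in place of 4-methylphenyl on this aromatic nitrogen, this assay shows a number 21.4 percentage points higher from compound 1 to compound 4 (beyond the scatter). An aromatic ring on this nitrogen is therefore not needed for inhibition of paw edema at this one dose, and a smaller chain with one double bond serves better here. Nothing shown explains the rise. Still open, on these data alone, is whether the gain comes from the allyl group itself or simply from losing the ring. A propyl chain, which has no double bond, or a benzyl group on this nitrogen would help separate the two.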